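This account rests on a few compounds, and the source may have more. Where it says the series, first, only, none or still open, it means among the compounds named here.

In a functional assay on M21 cells (Homo sapiens) for antiproliferative activity, read by sulforhodamine B assay, with a stated time of 48 h (a higher number here means a weaker inhibitor, a lower number a stronger inhibitor), compound 1 `CCCN1CCN(c2ccc(S(=O)(=O)Oc3ccccc3OC)cc2)C1=O` gives > 100000 nM, which is a limit of the assay and not a number. Compound 2 `CCCN1CCN(c2ccc(S(=O)(=O)Oc3ccc(C)cc3C)cc2)C1=O` gives 9700 nM, and compound 3 `CCCN1CCN(c2ccc(S(=O)(=O)Oc3c(Cl)cc(Cl)cc3Cl)cc2)C1=O` gives 56000 nM. Compound 3 therefore holds the higher of the two true numbers, and compound 2 is its nearest neighbour, with a 5.8-fold higher number from compound 2 to compound 3 (0.76 log units; beyond the scatter).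

Compound 4 `CCCN1CCN(c2ccc(S(=O)(=O)Oc3cccc(OC)c3)cc2)C1=O` has not yet been measured. Its change from compound 3 is 3-methoxyphenyl in place of 2,4,6-trichlorophenyl on an oxygen, so 3-methoxyphenyl takes the place of 2,4,6-trichlorophenyl on the oxygen bound to the sulfonyl sulfur. For the measured compounds named here, no measured step makes this exchange directly. The closest evidence comes from compound 1, which carries the related 2-methoxyphenyl group. Replacing that group gave an at least 10-fold lower number from compound 1 to compound 2 (1.01 log units; beyond the scatter) with 2,4-dimethylphenyl, a large change, but an at least 1.7-fold lower number from compound 1 to compound 3 (0.25 log units; that floor lies within the scatter) with 2,4,6-trichlorophenyl, a floor that does not clear the scatter. These steps give no firm reason to expect a large move in this assay, and at most a slight shift toward a lower number is anticipated. The expected change is a 1.6-fold lower number from compound 3 to compound 4 (0.20 log units; within the scatter). For compound 4 the estimated value is 35000 nM, with an expected range of 8000 nM to 100000 nM.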

Compound 4, half-maximal inhibitory concentration: 10000 nM
Estimate against measurement, compound 4: 3.5-fold (0.54 log units) above; measured number inside the range.
By their numbers in this assay, from the lowest: compounds 2 and 4 (each within the scatter of the next); then compound 3. At a limit, above all of these: compound 1.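

In this assay, for the compounds shown here, the exchange of 2,4,6-trichlorophenyl for 3-methoxyphenyl on the oxygen bound to the sulfonyl sulfur gives a 5.6-fold lower number from compound 3 to compound 4 (0.75 log units; beyond the scatter), the first direct reading of a methoxy-bearing group against the trichlorinated one. The 3-methoxyphenyl group also cannot be told apart from 2,4-dimethylphenyl, with a 1.0-fold higher number from compound 2 to compound 4 (0.01 log units; within the scatter), so two differently substituted rings now sit at the same level at this position. A methoxy group alone does not settle the outcome, since the two methoxyphenyl groups are separated by an at least 10-fold lower number from compound 1 to compound 4 (1.00 log units; beyond the scatter), and that step is only a floor, compound 1 being at a limit of the assay and not a number: the limit of > 100000 nM in this assay, at which 1 of the 4 values shown sits.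

The compounds shown do not explain why the two methoxyphenyl groups differ, and they do not show how far the level reached by compound 2 and compound 4 can be improved at this position. As far as these compounds go, a plain phenyl ring, a ring carrying an amine or a carboxylic acid, and a longer chain on the shared core all remain open.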